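This account rests on a few compounds, and the source may have more. Where it says the series, first, only, none or still open, it means among the compounds named here.

Of the compounds shown here, three that share one core have been tested in an ADME assay on microsomes from liver (Mus musculus) for metabolic stability, read by HPLC, with a stated time of 30 min; on this read-out higher numbers stand for a more stable compound and lower numbers for a less stable compound. Compound 1, with the structure `COc1ccc(NC(=O)C(=O)c2c[nH]c3cc(C(C)C)ccc23)cc1`, gives 86.2% in this assay. Compound 2, with the structure `Cc1ccc(NC(=O)C(=O)c2c[nH]c3cc(C(C)C)ccc23)cc1`, gives 82.6% in this assay. Compound 3, with the structure `COc1ccc(NC(=O)C(=O)c2c[nH]c3cc(C#N)ccc23)cc1`, gives 87.5% in this assay. Compound 2 differs from compound 1 by methyl in place of methoxy on an aromatic carbon. This change produced a number 3.6 percentage points lower from compound 1 to compound 2 (within the scatter). The two cores differ by cyano in place of isopropyl on an aromatic carbon. That difference produced a number 1.3 percentage points higher from compound 1 to compound 3 (within the scatter). All three numbers therefore sit close to one another.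

Compound 4, with the structure `Cc1ccc(NC(=O)C(=O)c2c[nH]c3cc(C#N)ccc23)cc1`, has not yet been measured. It differs from compound 3 by methyl in place of methoxy on an aromatic carbon, the same change that turns compound 1 into compound 2, made at the same place. The step to compound 4 is expected to be about as small as the earlier one: an estimated a number 3.5 percentage points lower from compound 3 to compound 4 (within the scatter), which rests on the earlier result a number 3.6 percentage points lower from compound 1 to compound 2 (within the scatter). On that basis compound 4 is expected to give 84% in this assay, with a range estimated from 74% to 92%.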

Compound 4, percent of the compound remaining: 88.2%
The estimate for compound 4 lay 4.2 percentage points below the measured number; low and high end bracket the measured number.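

On the core of compound 3, methyl in place of methoxy gives a number 0.7 percentage points higher from compound 3 to compound 4 (within the scatter) in this assay, and this step agrees with the one seen on the core of compound 1: the same change on two cores in this assay, a number 3.6 percentage points lower (within the scatter) from compound 1 to compound 2 and a number 0.7 percentage points higher (within the scatter) from compound 3 to compound 4, 4.3 percentage points apart, within the scatter of two such steps. Cyano in place of isopropyl gives a number 5.6 percentage points higher from compound 2 to compound 4 (within the scatter), and this step also agrees with its earlier counterpart: the same change on two cores in this assay, a number 1.3 percentage points higher (within the scatter) from compound 1 to compound 3 and a number 5.6 percentage points higher (within the scatter) from compound 2 to compound 4, 4.3 percentage points apart, within the scatter of two such steps. Each change therefore behaves alike on the two cores shown, but every step lies within the scatter, so this shows only that neither change has a measurable effect here, not that a real effect of fixed size carries from one core to another.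

The compounds shown leave open whether a group such as an amine, a carboxylic acid or a longer chain in place of the methoxy would move the number beyond the scatter. They also leave open whether the same agreement would hold on cores beyond these two, or for a change with a larger step.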